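Series notes: chain end change in the shared core

The source may hold more compounds than are shown below. What is called first, only, known or untested is meant among the compounds shown, and "the series" means these compounds.

Measured so far in an assay for inhibition of Fatty-acid amide hydrolase 1 (Rattus norvegicus); on this read-out higher numbers stand for weaker inhibition and lower numbers for stronger inhibition:
compound 1 `COC(=O)c1ccc(-c2cnc(C(=O)CCc3ccc(-c4ccccc4)cc3)o2)nc1` — 2.2 nM
compound 2 `O=C(CCc1ccc(-c2ccccc2)cc1)c1ncc(-c2cccnc2)o1` — 1.1 nM
compound 3 `NC(=O)c1ccc(-c2cnc(C(=O)CCc3ccc(-c4ccccc4)cc3)o2)nc1` — 1.3 nM

Compound 1 holds the highest of the three numbers, yet its gaps are small: a 1.7-fold lower number from compound 1 to compound 3 (0.23 log units; within the scatter) and a 2.0-fold lower number from compound 1 to compound 2 (0.30 log units; within the scatter), both within the scatter, as is a 1.2-fold higher number from compound 2 to compound 3 (0.07 log units; within the scatter). All three steps alter the heteroaryl end of the core and leave the chain end untouched.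

Compound 4 `COC(=O)c1ccc(-c2cnc(C(=O)CCc3ccc(COc4ccccc4)cc3)o2)nc1` differs from compound 1 at that untouched end: phenoxymethyl in place of phenyl on an aromatic carbon. Among the measured compounds shown here, no measured pair in this set changes the chain end, so none of the three steps bears on this change, and no direction can be read from them. The three steps show only that the heteroaryl end tolerates substitution with little movement in this assay. The chain end is a different region, and the step there is estimated to be a modest weakening at most, with wide uncertainty.

Compound 4 is expected to give about 5 nM in this assay, within 1 nM to 25 nM, an expected step of a 2.3-fold higher number from compound 1 to compound 4 (0.36 log units; beyond the scatter).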

Compound 4, inhibition constant: 3.5 nM
Estimate against measurement, compound 4: 1.4-fold (0.15 log units) above; the measured number falls inside the stated range.
By their numbers in this assay, from the lowest: compounds 2, 3, 1 and 4 (each within the scatter of the next, the first and the last beyond it).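

In this assay, the chain end now has its first measured step, with phenoxymethyl in place of phenyl giving a 1.6-fold higher number from compound 1 to compound 4 (0.20 log units; within the scatter) on an aromatic carbon para to a large group. The earlier compounds shown here changed only the heteroaryl end, whereas this pair shows that a larger group carrying a hydrogen-bond acceptor can enter at the chain end with no change beyond the scatter. No supporting data bear on why this change leaves the number within the scatter.

As far as these compounds go, whether the same tolerance holds when phenoxymethyl is paired with the heteroaryl ends of compound 2 or compound 3 remains open. Also open, from the compounds shown here alone, is how the read-out responds at this position to an amine, a carboxylic acid or a longer chain ending in phenyl, since a single step cannot define the limits of the chain end.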